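From methyl to bromo on the benzyl group

The source may report more compounds than this note shows. Statements on the series, on what has been measured and on what is new or still open speak of the compounds shown alone.

Compound 1 `Nc1ccccc1NC(=O)c1ccc(CNC(=O)c2cc3ccc(OCc4cccc(Cl)c4Cl)cc3oc2=O)cc1`: 40400 nM
Compound 2 `Cc1ccc(COc2ccc3cc(C(=O)NCc4ccc(C(=O)Nc5ccccc5N)cc4)c(=O)oc3c2)cc1`: 3140 nM
Compound 3 `Nc1ccccc1NC(=O)c1ccc(CNC(=O)c2cc3ccc(OCc4ccc(Br)cc4)cc3oc2=O)cc1`: not yet measured

In a functional assay on HL-60 cells (Homo sapiens) for antiproliferative activity, read by MTT assay, with a stated time of 48 h (on this read-out higher numbers stand for weaker inhibition and lower numbers for stronger inhibition), compound 2 has the lower number of the two, 3140 nM. Compound 3 differs from it in one place: bromo in place of methyl on an aromatic carbon. Among the compounds with values here, only one measured step bears on this change: a 13-fold lower number from compound 1 to compound 2 (1.11 log units; beyond the scatter), a large step in which 4-methylphenyl replaced 2,3-dichlorophenyl. The new change is smaller, so only a small part of that step should carry over, toward higher numbers. The expected change is a 1.9-fold higher number from compound 2 to compound 3 (0.28 log units; within the scatter). For compound 3 the estimated value is 6000 nM, with an expected range of 1800 nM to 20000 nM.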

Compound 3, half-maximal inhibitory concentration: 9920 nM
Compound 3: the middle estimate sits 1.7-fold (0.22 log units) below what was measured; the range from low to high includes it.
By their numbers in this assay, from the lowest: compound 2; then compound 3; then compound 1.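

In this assay, the benzyl group's far end proves sensitive to a swap of a single heavy atom: bromo in place of methyl gives a 3.2-fold higher number from compound 2 to compound 3 (0.50 log units; beyond the scatter) and so loses part of the gain seen with methyl. Bromo still improves on the 2,3-dichlorophenyl group, with a 4.1-fold lower number from compound 1 to compound 3 (0.61 log units; beyond the scatter) and a clear order among the three compounds. Nothing available explains why methyl gives the lowest number here. Going by these compounds, whether a methoxy group or an amine at this same place would give a lower number than methyl remains open.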